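This account rests on a few compounds, and the source may have more. Where it says the series, first, only, none or still open, it means among the compounds named here.

Measured compounds:
Compound 1 `c1coc(-c2ccnc(Nc3ccc(-n4ccnc4)cc3)n2)c1` with 2200 nM in a functional assay for inhibition, with Homo sapiens as the target; on this read-out lower numbers stand for stronger inhibition and higher numbers for weaker inhibition.
Compound 2 `CN(C)c1ccc(Nc2nccc(-c3ccco3)n2)cc1` with 1900 nM in this assay.
Compound 3 `COc1cccc(Nc2nccc(-c3ccsc3)n2)c1` with 1800 nM in this assay.

Compound 3 sits at the low end of these three numbers, yet its distance to compound 2 and to compound 1 is within the scatter each time, so the three compounds are not separated from one another in this assay.

Compound 4 `COc1cccc(Nc2nccc(-c3cccs3)n2)c1` is not yet measured. It differs from compound 3 in one place: thiophen-2-yl in place of thiophen-3-yl on an aromatic carbon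

Within the data shown here, only one step is known among the measured compounds, a 1.2-fold lower number from compound 1 to compound 2 (0.06 log units; within the scatter), and it changes a group on the other side of the shared core, not the thiophen-3-yl. Among the measured compounds shown here, no measured pair exchanges thiophen-3-yl for thiophen-2-yl, so nothing known bears directly on this change. The three measured numbers all lie within the scatter of one another, and on that basis no step beyond the scatter is expected for compound 4 in this assay, that is no change at the digits printed from compound 3 to compound 4 (within the scatter) as the expected step. Compound 4 is therefore estimated at 1800 nM, with a range from 700 nM to 4500 nM.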

Compound 4, half-maximal inhibitory concentration: 900 nM
Estimate against measurement, compound 4: 2.0-fold (0.30 log units) above, and the stated range covers the measured number.
By their numbers in this assay, from the lowest: compounds 4, 3, 2 and 1 (each within the scatter of the next, the first and the last beyond it).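

In this assay, exchanging thiophen-3-yl for thiophen-2-yl, with the same atoms joined differently, gives a 2.0-fold lower number from compound 3 to compound 4 (0.30 log units; within the scatter). This is the first step shown at this position, the aromatic carbon that carries the thiophene, as the only earlier step lay on the other side of the shared core. It shows that the point of attachment of the thiophene can change without the two compounds being separated in this assay, and nothing available accounts for the size of this step.

The compounds shown leave open whether a simple amine, a carboxylic acid or a phenyl group on this same carbon would give a step beyond the scatter. They also leave open whether thiophen-2-yl and thiophen-3-yl would compare in the same way with dimethylamino or 1H-imidazol-1-yl on the other side of the core.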